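Changing a methoxy to dimethylamino on two different cores

A few compounds are considered here, and "the series" means these few. Any claim that something is new, unique, unknown or untested is made for them only; others in the source may bear on it.

Measured so far:
compound 1 `COc1ccc(/C=C2\CCCc3ccccc3C2=O)cc1`, 340 nM
compound 2 `CN(C)c1ccc(/C=C2\CCCc3ccccc3C2=O)cc1`, 1870 nM
compound 3 `COc1ccc(/C=C2\CCCCCC2=O)cc1`, 306000 nM

These values come from a functional assay on L1210 cells (Mus musculus) for inhibition; on this read-out lower numbers stand for stronger inhibition and higher numbers for weaker inhibition. Compound 1 and compound 2 share a core and differ by dimethylamino in place of methoxy on an aromatic carbon; that change gave a 5.5-fold higher number from compound 1 to compound 2 (0.74 log units; beyond the scatter). Compound 3 carries the other core, and the difference between the two cores is not broken down here. Compound 4 `CN(C)c1ccc(/C=C2\CCCCCC2=O)cc1` is not yet measured; it differs from compound 3 by dimethylamino in place of methoxy on an aromatic carbon. The two changes are of the same kind, though the surroundings are worded differently: para to a large group in the first pair, para to a group of 9 heavy atoms in the second. If the step repeats, compound 4 would give a 3.9-fold higher number from compound 3 to compound 4 (0.59 log units; beyond the scatter), an expectation resting on a 5.5-fold higher number from compound 1 to compound 2 (0.74 log units; beyond the scatter). So for compound 4 the estimate in this assay is 1200000 nM, with a range from 300000 nM to 4000000 nM.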

Compound 4, half-maximal inhibitory concentration: 79100 nM
Beside the measured number, compound 4's estimate is 15-fold (1.18 log units) above it; the measured number lies below the stated range.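

In this assay the same swap of methoxy for dimethylamino gave a 3.9-fold lower number from compound 3 to compound 4 (0.59 log units; beyond the scatter), so on this second core the number moved the opposite way. The two steps do not agree: the same change on two cores in this assay, a 5.5-fold higher number (0.74 log units; beyond the scatter) from compound 1 to compound 2 and a 3.9-fold lower number (0.59 log units; beyond the scatter) from compound 3 to compound 4, 21-fold (1.33 log units) apart, beyond the scatter of two such steps. This shows that the result of this change on one core cannot simply be carried over to the other in this series, but two pairs do not show which feature of the cores lies behind the difference.

The compounds shown leave open how another group on that aromatic carbon, such as a hydroxyl or a fluorine, would behave on each core. They also leave open whether a third core would follow the first pair, the second, or neither.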